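Aryl urea cyclohexyl ethers: methoxy against methylsulfanyl

The compounds below may be only part of what the source reports. "The series", "measured", "known", "first", "only" and "open" are said of these compounds alone.

Three compounds have numbers in a functional assay on CRL2813 cells (Homo sapiens) for cytotoxicity, read by sulforhodamine B assay, with a stated time of 5 days; on this read-out higher numbers stand for weaker inhibition and lower numbers for stronger inhibition. Compound 1 `O=C(Nc1cccc(C(F)(F)F)c1)N[C@H]1CC[C@H](Oc2ccc(C(F)(F)F)cc2)CC1` gives 460 nM, and compound 3 `O=C(Nc1cccc(C(F)(F)F)c1)N[C@H]1CC[C@H](Oc2ccc(Cl)cc2)CC1` gives 2000 nM; the step between them is a 4.3-fold higher number from compound 1 to compound 3 (0.64 log units; beyond the scatter). Compound 2 `COc1cccc(NC(=O)N[C@H]2CC[C@H](Oc3ccc(F)cc3)CC2)c1` gives 14000 nM, the highest of the three numbers, with compound 3 nearest and compound 1 furthest from it. Compound 4 `CSc1cccc(NC(=O)N[C@H]2CC[C@H](Oc3ccc(F)cc3)CC2)c1` differs from compound 2 by methylsulfanyl in place of methoxy on an aromatic carbon. Among the measured compounds shown here, no measured step touches this part of the shared core: the only known step sits on the other aromatic ring and says nothing about this exchange. The expectation is therefore a step no larger than the scatter, so the expected step to compound 4 is no change at the digits printed from compound 2 to compound 4 (within the scatter). Compound 4 is estimated at 14000 nM, in a range from 4000 nM to 50000 nM.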

Compound 4, half-maximal inhibitory concentration: 11100 nM
Compound 4: the middle estimate sits 1.3-fold (0.10 log units) above what was measured, within the range that was stated.
By their numbers in this assay, from the lowest: compound 1; then compound 3; then compounds 4 and 2 (each within the scatter of the next).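

In this assay, among the compounds shown here, methylsulfanyl in place of methoxy gives a 1.3-fold lower number from compound 2 to compound 4 (0.10 log units; within the scatter), the first measured step at this position of the shared core. Sulfur for oxygen in this group therefore leaves the two compounds indistinguishable in this assay. Nothing at hand explains this result.

Open, as far as these compounds go, is whether a group of another kind here, such as an amine or a carboxylic acid, would shift the number. Also open, from the compounds shown here alone, is whether methoxy and methylsulfanyl would read alike with chloro or trifluoromethyl on the other aromatic ring.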